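The compounds below may be only part of what the source reports. "The series", "measured", "known", "first", "only" and "open" are said of these compounds alone.

Compounds measured:
compound 1, `ClCc1ccc(Cn2cnc3c(Cl)ncnc32)cc1`, 28800 nM
compound 2, `ClCc1cccc(Cn2cnc3c(Cl)nc(Cl)nc32)c1`, 3460 nM
compound 3, `Nc1nc(Cl)c2ncn(Cc3ccccc3CCl)c2n1`, 38000 nM

The account follows compound 1, `ClCc1ccc(Cn2cnc3c(Cl)ncnc32)cc1`, which in a functional assay on UACC-257 cells (Homo sapiens) for cytotoxicity, read by sulforhodamine B assay, with a stated time of 48 h (a higher number here means a weaker inhibitor of growth, a lower number a stronger inhibitor of growth), gives 28800 nM. Among the three numbers this is the second highest. The nearest is compound 3 with 38000 nM, a slightly higher number that lies within the usual scatter, so the two cannot be told apart. The furthest is compound 2 with 3460 nM, a far lower number and a gap well beyond the scatter; compound 2 is thus the strongest growth inhibitor of the three measured.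

Compound 4, `Nc1nc(Cl)c2ncn(Cc3ccc(CCl)cc3)c2n1`, has not yet been measured. It differs from compound 1 in one place: amino in place of hydrogen on an aromatic carbon. Going by the values given here, no measured pair isolates this change. Compound 3, which carries the same amino group though with the chloromethyl group on a differently placed position of the benzyl ring, gives 38000 nM, close to compound 1. On that basis the step is expected to be small, with no direction beyond the scatter: the estimated step is a 1.0-fold higher number from compound 1 to compound 4 (0.02 log units; within the scatter). Compound 4 is therefore estimated at 30000 nM, within a range from 10000 nM to 90000 nM.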

Compound 4, concentration for total growth inhibition: 47900 nM
Beside the measured number, compound 4's estimate is 1.6-fold (0.20 log units) below it; the range from low to high includes it.
By their numbers in this assay, from the lowest: compound 2; then compounds 1, 3 and 4 (each within the scatter of the next).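

In this assay, the amino group in place of hydrogen on the aromatic carbon between two ring nitrogen atoms can now be read directly from a matched pair. The step is a 1.7-fold higher number from compound 1 to compound 4 (0.22 log units; within the scatter) and so cannot be told apart from the usual scatter, which shows that this position accepts the amino group with no measurable shift in growth inhibition. No measurement shown here offers an explanation for this result.

The compounds shown leave open whether a larger or different group at this position, such as methylamino, dimethylamino, hydroxyl or methoxy, would also leave the number within the scatter. They also leave open whether any replacement here could produce a step beyond the scatter from compound 1.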